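A few compounds are considered here, and "the series" means these few. Any claim that something is new, unique, unknown or untested is made for them only; others in the source may bear on it.

Compound 1 `COc1cc2c(/C=C3/C(=O)Nc4ccc(O)cc43)c(Cl)n(Cc3cc(OC)c(OC)c(OC)c3)c2cc1C` gives 1410 nM in a functional assay on cells (Cancer cell lines, Homo sapiens) for cytotoxicity, with a stated time of 48 h; a higher number here means a weaker inhibitor of growth, a lower number a stronger inhibitor of growth.
Compound 2 `COc1cc2c(/C=C3/C(=O)Nc4ccc(Cl)cc43)c(Cl)n(Cc3cc(OC)c(OC)c(OC)c3)c2cc1C` gives 2090 nM.
Compound 3 `COc1c(/C=C2/C(=O)Nc3ccccc32)c2ccccc2n1-c1ccccc1` gives 1230 nM.

Compound 3 shows the smallest of these three numbers, yet its gaps to compound 1 and to compound 2 both lie within the scatter, so the three cannot be told apart. Compound 4 `COc1c(/C=C2/C(=O)Nc3ccc(Cl)cc32)c2ccccc2n1-c1ccccc1` is compound 3 with chloro in place of hydrogen on an aromatic carbon. Within the data shown here, the only measured step that touches a chloro at this kind of position is the one where a 1.5-fold higher number from compound 1 to compound 2 (0.17 log units; within the scatter); there chloro replaced hydroxy, not hydrogen, and on a different core, so it bears only loosely. Among the measured compounds shown here, no measured step puts chloro in place of hydrogen. The step of a 1.1-fold higher number from compound 3 to compound 4 (0.02 log units; within the scatter) is therefore expected to stay within the scatter. Compound 4 is estimated at 1300 nM, with a range from 500 nM to 3500 nM.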

Compound 4, concentration for 50% growth inhibition: 4270 nM
Beside the measured number, compound 4's estimate is 3.3-fold (0.52 log units) below it; the whole stated range lies below it.
By their numbers in this assay, from the lowest: compounds 3, 1 and 2 (each within the scatter of the next); then compound 4.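

In this assay, chloro in place of hydrogen on this aromatic carbon gives a 3.5-fold higher number from compound 3 to compound 4 (0.54 log units; beyond the scatter) on this core, so growth inhibition here does respond to a change at this position. The earlier step at this position, a 1.5-fold higher number from compound 1 to compound 2 (0.17 log units; within the scatter) with chloro replacing hydroxy on another core, stayed within the scatter and started from a different group. Nothing available explains the new step.

On these data alone, whether fluoro or an amine at this position would behave like chloro remains open. So does whether chloro in place of hydrogen would give a similar step on the core of compound 1.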